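A few compounds are considered here, and "the series" means these few. Any claim that something is new, unique, unknown or untested is made for them only; others in the source may bear on it.

Compound 1, `CCCCCCCC(CCO)n1cnc2c(Cl)nc(Cl)nc21`, gives 13600 nM in a functional assay on SW480 cells (Homo sapiens) for antiproliferative activity, read by MTT assay, with a stated time of 48 h; on this read-out higher numbers stand for weaker inhibition and lower numbers for stronger inhibition. Compound 2, `CCCCCCCCC(CCO)n1cnc2c(Cl)nc(Cl)nc21`, gives 24000 nM in this assay; the two differ only by methyl in place of hydrogen on a saturated chain carbon, eight bonds along the chain from an aromatic nitrogen, and the step between them is a 1.8-fold higher number from compound 1 to compound 2 (0.25 log units; within the scatter). Compound 3, `CCCCCCCCCCCC(CCO)n1cnc2c(Cl)ncnc21`, gives 5290 nM in this assay, the lowest of the three numbers; its difference from compound 1 is not broken down here, as the two cores and chains differ in more than one place.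

Compound 4, `CCCCCCCCCCCCC(CCO)n1cnc2c(Cl)ncnc21`, is not yet measured in this assay. It differs from compound 3 by methyl in place of hydrogen on a saturated chain carbon, ten or more bonds along the chain from an aromatic nitrogen. This is the same kind of change as that from compound 1 to compound 2, but the place on the chain is not the same. Within the data shown here, the step from compound 3 to compound 4 is expected to be a 1.4-fold higher number from compound 3 to compound 4 (0.15 log units; within the scatter), resting on the step of a 1.8-fold higher number from compound 1 to compound 2 (0.25 log units; within the scatter) as the only measured example of this kind of change. Compound 4 is therefore expected to give about 7500 nM in this assay, within 3500 nM to 17000 nM.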

Compound 4, half-maximal inhibitory concentration: > 50000 nM
Compound 4: only a limit was reported; the forecaster's own chance of this, stated with the estimate: 5%; at least 6.6-fold (0.82 log units) between middle value and limit.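

In this assay the step is an at least 9.4-fold higher number from compound 3 to compound 4 (0.97 log units; beyond the scatter), and compound 4 stands at a limit of the assay, so the size of this step is a floor and not a number: the limit of > 50000 nM in this assay, at which 1 of the 4 values shown sits. The same change does not keep its size from the core and chain of compound 1 to those of compound 3: the same change on two cores in this assay, a 1.8-fold higher number (0.25 log units; within the scatter) from compound 1 to compound 2 and an at least 9.4-fold higher number (0.97 log units; beyond the scatter) from compound 3 to compound 4, at least 5.3-fold (0.72 log units) apart, beyond the scatter of two such steps. This rests on one pair on each side, and the pairs differ in both core and chain, so it shows that the earlier step cannot be carried over at face value here, but not whether the core, the chain or the place of the change sets the gap.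

Still open, from the compounds shown here alone, is whether a still longer chain on the core of compound 3 stays at the same limit, or whether the chain of compound 4 on the core of compound 1 behaves alike. Also open, going by these compounds, is how an amine or a carboxylic acid in place of the hydroxyl would read in this assay.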